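The compounds below may be only part of what the source reports. "The series", "measured", "known", "first", "only" and "open" are said of these compounds alone.

Measured compounds:
compound 1 `NS(=O)(=O)c1ccc2nc(-n3nc(C(F)(F)F)cc3-c3ccc(Br)cc3)sc2c1` with 60% in a functional assay on the whole organism (strain Wistar albino) for inhibition, with Rattus norvegicus as the target, read by paw edema, with stated times of 30 min and 3 h, at a dose of 50 mg/kg by the oral route; a higher number here means more inhibition at the dose given (going by the name of the read-out), a lower number less inhibition;
compound 2 `NS(=O)(=O)c1ccc2nc(-n3nc(C(F)(F)F)cc3-c3ccc(F)cc3)sc2c1` with 64%.

Going by the values given here, only two compounds have been measured, and compound 2 stands together with compound 1, the two numbers within the scatter of each other; the one measured step, a number 4 percentage points higher from compound 1 to compound 2 (within the scatter), is the sole reference available. Compound 3 `NS(=O)(=O)c1ccc2nc(-n3nc(C(F)(F)F)cc3-c3cccs3)sc2c1` is the unmeasured compound, and its change from compound 2 is thiophen-2-yl in place of 4-fluorophenyl on an aromatic carbon. Among the compounds with values here, no measured step concerns a swap of this kind; the only step on record exchanges one halogen for another on the same aromatic carbon and stays within the scatter, so it bears on the new step only loosely. With that thin basis the expectation is no clear movement beyond the scatter, the step estimated as a number 6 percentage points lower from compound 2 to compound 3 (within the scatter). Compound 3 is therefore expected to give about 58%, within a range from 45% to 70%.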

Compound 3, a percentage reported as inhibition, in the whole organism at one dose (the size of the read-out at that dose, not a potency): 49%
Compound 3: middle estimate off by 9 percentage points, on the high side; the range from low to high includes it.
By their numbers in this assay, from the lowest: compound 3; then compounds 1 and 2 (each within the scatter of the next).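

At this aromatic carbon of the five-membered aromatic ring with 2 nitrogen, exchanging one halogen for another had left this assay within the scatter, but replacing the whole aryl group does not: thiophen-2-yl in place of 4-fluorophenyl gives a number 15 percentage points lower from compound 2 to compound 3 (beyond the scatter), and thiophen-2-yl in place of 4-bromophenyl gives a number 11 percentage points lower from compound 1 to compound 3 (beyond the scatter). The position therefore responds to a change of the ring itself, and both steps point the same way, whichever halogen-bearing group leaves. Nothing measured here explains this drop.

As far as these compounds go, it remains open whether the step belongs to the thiophen-2-yl group itself or simply to the loss of the halogen-bearing phenyl group. A plain phenyl or a furan-2-yl group at this carbon would help separate the two.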